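The source may report more compounds than this note shows. Statements on the series, on what has been measured and on what is new or still open speak of the compounds shown alone.

The numbers come from a functional assay on U-251 cells (Homo sapiens) for cytotoxicity, read by sulforhodamine B assay, with a stated time of 48 h, tested at 0.01 uM; a lower number here means a stronger effect, a higher number a weaker effect of the compound at the concentration tested.

Compound 1, `COc1cc(-c2cc(/C=C/C(=O)c3ccc(Cl)c(Cl)c3)[nH]n2)cc(OC)c1OC`, gives 97%.
Compound 2, `COc1ccc(-c2cc(/C=C/C(=O)c3ccc(N)cc3)[nH]n2)cc1OC`, gives 95%.
Compound 3, `COc1ccc(C(=O)/C=C/c2cc(-c3cc(OC)c(OC)c(OC)c3)n[nH]2)cc1`, gives 97%.

Compound 3 stands level with compound 1 at the digits shown, and these two together are the highest of the three numbers; compound 2 lies within the scatter of both, so no order among the three can be drawn. Going by the values given here, the step of no change at the digits printed from compound 1 to compound 3 (within the scatter) is the one measured change at this position, and it stayed within the scatter.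

Compound 4, `COc1cc(-c2cc(/C=C/C(=O)c3ccc(F)c(F)c3)[nH]n2)cc(OC)c1OC`, differs from compound 3 by 3,4-difluorophenyl in place of 4-methoxyphenyl on a carbonyl carbon. Among the compounds with values here, the only measured step that bears on this place, from compound 1 to compound 3, brought no change beyond the scatter when a dihalogenated phenyl was swapped for the methoxyphenyl, and compound 4 reverses that kind of swap. The step of a number 1 percentage points lower from compound 3 to compound 4 (within the scatter) is therefore expected to stay within the scatter. For compound 4 the estimate in this assay is 96%, with a range from 88% to 100%.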

Compound 4, a percentage reported as activity, at one concentration (the size of the read-out at that concentration, not a potency): 97%
Estimate against measurement, compound 4: 1 percentage points below, and the stated range covers the measured number.
By their numbers in this assay, from the lowest: compounds 2, 1, 3 and 4 (each within the scatter of the next).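

In this assay, 3,4-difluorophenyl in place of 4-methoxyphenyl on a carbonyl carbon gives a flat result (no change at the digits printed from compound 3 to compound 4 (within the scatter)), and 3,4-difluorophenyl in place of 3,4-dichlorophenyl at that same place does too (no change at the digits printed from compound 1 to compound 4 (within the scatter)). The place on the carbonyl carbon now carries three different aromatic groups on one shared core, and none of them can be told apart from the others by this read-out, so the exchange of one halogen for another joins the exchange of halogens for methoxy as a change without a visible result. Nothing available offers an explanation for this flat outcome.

Going by these compounds, whether the three groups would separate at a higher concentration remains open. So does the question of whether a carboxylic acid or a piperidine at this place, instead of a substituted phenyl, would read the same.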